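The source may report more compounds than this note shows. Statements on the series, on what has been measured and on what is new or still open speak of the compounds shown alone.

Measured so far:
compound 1 `COc1cc2ncnc(N3CCc4ccccc43)c2cc1NC(=O)C=C(C)C` — 6270 nM
compound 2 `CC/C=C/C(=O)Nc1cc2c(N3CCc4ccccc43)ncnc2cc1OC` — 2470 nM
compound 3 `CCN(CC)C/C=C/C(=O)Nc1cc2c(N3CCc4ccccc43)ncnc2cc1OC` — 1690 nM

Compound 3 sits at the low end of the three numbers in a functional assay on A549 cells (Homo sapiens) for antiproliferative activity, read by MTT assay, with a stated time of 72 h; on this read-out lower numbers stand for stronger inhibition and higher numbers for weaker inhibition. Its separation from compound 1 is real: a 3.7-fold lower number from compound 1 to compound 3 (0.57 log units; beyond the scatter). Against compound 2 it is not separated, since a 1.5-fold lower number from compound 2 to compound 3 (0.16 log units; within the scatter), so compounds 2 and 3 are to be read as equivalent on this read-out.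

Compound 4 `COc1cc2ncnc(N3CCc4ccccc43)c2cc1NC(=O)/C=C/CN1CCCC1` has not yet been measured. It differs from compound 3 in one place: pyrrolidin-1-yl in place of diethylamino on a saturated chain carbon bound to a double-bonded chain carbon.

Which measured steps bear on this? Going by the values given here, only the terminal part of the chain on the amide carbonyl has been varied. a 2.5-fold lower number from compound 1 to compound 2 (0.40 log units; beyond the scatter) and a 3.7-fold lower number from compound 1 to compound 3 (0.57 log units; beyond the scatter) both replace the branched alkene with a straight one and are the only steps beyond the scatter. a 1.5-fold lower number from compound 2 to compound 3 (0.16 log units; within the scatter), the closest analogue to the present change, is within the scatter. Among the compounds with values here, no measured pair swaps one amine for another. The step from compound 3 to compound 4 therefore is expected to be none beyond the scatter, a 1.0-fold higher number from compound 3 to compound 4 (0.00 log units; within the scatter).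

Compound 4 is estimated at 1700 nM in this assay, within a range of 800 nM to 3600 nM.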

Compound 4, half-maximal inhibitory concentration: 1210 nM
The estimate for compound 4 lay 1.4-fold (0.15 log units) above the measured number; the measured number falls inside the stated range.
By their numbers in this assay, from the lowest: compounds 4, 3 and 2 (each within the scatter of the next, the first and the last beyond it); then compound 1.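

In this assay, compound 4 gives the only swap of one amine for another among the compounds shown, and a 1.4-fold lower number from compound 3 to compound 4 (0.15 log units; within the scatter) means that closing diethylamino into pyrrolidin-1-yl, with the same heavy-atom count on a saturated chain carbon bound to a double-bonded chain carbon, leaves the read-out unresolved. The amine-for-methyl change at this carbon now clears the scatter, with a 2.0-fold lower number from compound 2 to compound 4 (0.31 log units; beyond the scatter) for pyrrolidin-1-yl, whereas the diethylamino analogue compound 3 stayed within it against compound 2; since compounds 3 and 4 cannot be told apart, this gives no ranking of the two amines, and a 5.2-fold lower number from compound 1 to compound 4 (0.71 log units; beyond the scatter) is still a modest step against the 2-methylprop-1-en-1-yl amide. Nothing measured alongside these numbers accounts for any of these steps.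

Still open, as far as these compounds go, is whether other amines on this carbon, such as dimethylamino, piperidin-1-yl or morpholin-4-yl, stay level with compounds 3 and 4 or move away from them. A longer chain carrying the pyrrolidin-1-yl group, and changes to the shared core with this chain held constant, also remain unexplored in the compounds shown here.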